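Swapping the Fluorinated Ring for a Hydroxy-Methoxy Ring

The compounds below may be only part of what the source reports. "The series", "measured", "known", "first", "only" and "open" are said of these compounds alone.

Measured compounds:
compound 1 `OC[C@H]1O[C@@H](n2cnc3c(NCc4ccc(F)cc4)ncnc32)[C@H](O)[C@@H]1O`: 13200 nM in a functional assay on HOS cells (Homo sapiens) for antiproliferative activity, with a stated time of 72 h; on this read-out higher numbers stand for weaker inhibition and lower numbers for stronger inhibition
compound 2 `OC[C@H]1O[C@@H](n2cnc3c(NCc4c(F)ccc(F)c4F)ncnc32)[C@H](O)[C@@H]1O`: "not determined" (no result reported) in this assay

Compound 2 therefore stands at no number on these data; only compound 1, sharing the same core, gives 13200 nM in this assay, a weak result. Compound 3 `COc1cccc(CNc2ncnc3c2ncn3[C@@H]2O[C@H](CO)[C@@H](O)[C@H]2O)c1O` differs from compound 2 by one change: 2-hydroxy-3-methoxyphenyl in place of 2,3,6-trifluorophenyl on a saturated chain carbon bound to a nitrogen on an aromatic ring. Among the measured compounds shown here, with no measured step to lean on, no shift in this assay beyond the scatter is expected from this change, and the weak number for compound 1 suggests this series inhibits poorly. Compound 3 is estimated at 15000 nM, within 3000 nM to 60000 nM.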

Compound 3, half-maximal inhibitory concentration: > 166000 nM
Compound 3 gave a limit, no number (the forecaster's own chance of this, stated with the estimate: 30%); middle value at least 11-fold (1.04 log units) away from the limit.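

Replacing 4-fluorophenyl with 2-hydroxy-3-methoxyphenyl gives an at least 12-fold higher number from compound 1 to compound 3 (1.09 log units; beyond the scatter) in this assay, so the aromatic group on this saturated chain carbon clearly shapes the result. Within this series, the change moves the read-out towards weaker inhibition. The reading for compound 3 is a limit, not a number: the limit of > 166000 nM in this assay, at which 1 of the 3 values shown sits.

The hydroxy and methoxy groups arrive together, so it stays open which of them accounts for the step. The compounds shown also leave open how a ring bearing an amine or a carboxylic acid, or a longer chain at this place, would read.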